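Working notes: replacing pyrrolidin-1-yl on the compound 3 scaffold

This account rests on a few compounds, and the source may have more. Where it says the series, first, only, none or still open, it means among the compounds named here.

Values in a physicochemical assay for lipophilicity, at pH 7.4; on this read-out higher numbers stand for higher lipophilicity and lower numbers for lower lipophilicity:
compound 1 `Cc1cc(Cl)c(C(=O)NC(=O)Nc2nc3ccc(S(=O)(=O)C4CCN(C)CC4)cc3s2)cc1-n1cccn1` gives 2.5
compound 2 `CN1CCC(S(=O)(=O)c2ccc3nc(NC(=O)NC(=O)c4cc(-n5cccn5)ccc4Cl)sc3c2)CC1` gives 2.3
compound 3 `CCOc1cc(Cl)c(C(=O)NC(=O)Nc2nc3ccc(CN4CCN(C)CC4)cc3s2)cc1N1CCCC1` gives 4

Compound 3 stands highest of the three, and compound 1 and compound 2 both lie lower, beyond the scatter. The next compound, not yet measured, is compound 4 `CCOc1cc(Cl)c(C(=O)NC(=O)Nc2nc3ccc(CN4CCN(C)CC4)cc3s2)cc1-c1ccn[nH]1`. The change is 1H-pyrazol-5-yl in place of pyrrolidin-1-yl on an aromatic carbon, ortho to an ethoxy group and para to a chloro group.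

Within the data shown here, the only measured step is a number 0.20 log units lower from compound 1 to compound 2 (within the scatter), hydrogen in place of methyl on an aromatic carbon. It lies within the scatter and concerns a different group, so it offers little guidance here. Among the measured compounds shown here, no measured step exchanges pyrrolidin-1-yl. Some guidance comes from the values alone: compound 3 stands at 4, while compound 1 at 2.5 and compound 2 at 2.3 carry a five-membered aromatic ring with 2 hetero atoms and read lower. Both also differ from compound 3 elsewhere, so only part of that gap is expected to carry over.

In this assay the expected step is a number 0.90 log units lower from compound 3 to compound 4 (beyond the scatter), a fall beyond the scatter but smaller than those gaps. The estimate for compound 4 is 3.1, with an expected range from 2.5 to 3.7.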

Compound 4, distribution coefficient: 3.9
Estimate against measurement, compound 4: 0.80 log units below; the measured number lies above the stated range.
By their numbers in this assay, from the lowest: compounds 2 and 1 (each within the scatter of the next); then compounds 4 and 3 (each within the scatter of the next).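

Read in this assay this exchange gives a number 0.10 log units lower from compound 3 to compound 4 (within the scatter) and is the first direct reading at this place, on an aromatic carbon ortho to an ethoxy group and para to a chloro group. On the compound 3 scaffold, a five-membered non-aromatic ring with 1 hetero atom and a five-membered aromatic ring with 2 hetero atoms therefore cannot be told apart on this read-out, even though the entering group brings 1 hydrogen-bond donor and the leaving group brings none. Whatever separates compound 1 and compound 2 from compound 3 is not shown by this exchange, and nothing at hand explains why the number holds here.

Open, from the compounds shown here alone, is whether this place stays as undemanding for a group of another kind, such as a carboxylic acid or a primary amine, which would test the same position on the same scaffold. Also open, going by these compounds, is whether the exchange of pyrrolidin-1-yl for 1H-pyrazol-5-yl reads the same on another core, such as that of compound 1, where the rest of the molecule differs.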